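Working notes: methyl for hydrogen on the urea phenyl of compound 3

The source may report more compounds than this note shows. Statements on the series, on what has been measured and on what is new or still open speak of the compounds shown alone.

Measured compounds:
compound 1 `O=C(NCc1ccccc1)N(Cc1ccccn1)n1cnnc1` — 31000 nM in a functional assay on B16-F10 cells (Mus musculus) for cytotoxicity, read by MTT assay, with a stated time of 48 h; on this read-out lower numbers stand for stronger inhibition and higher numbers for weaker inhibition
compound 2 `COc1ccc(CN(C(=O)Nc2ccc(C#N)cc2)n2cnnc2)cc1OC` — its value in this assay is a limit, > 50000 nM, not a number the limit of > 50000 nM in this assay, at which 1 of the 3 values shown sits.
compound 3 `O=C(Nc1ccccc1)N(Cc1ccccn1)n1cnnc1` — 23700 nM in this assay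

Compound 3 stands lowest of the two numbers; its nearest neighbour is compound 1, and that gap is within the scatter. For the measured compounds named here, the only single-point step measured is a 1.3-fold lower number from compound 1 to compound 3 (0.12 log units; within the scatter), a change at the urea nitrogen, not on the phenyl ring.

Compound 4 `Cc1ccc(NC(=O)N(Cc2ccccn2)n2cnnc2)cc1` differs from compound 3 by methyl in place of hydrogen on an aromatic carbon. Going by the values given here, no measured step touches this kind of change, so no step beyond the scatter is expected in this assay, in either direction. The step from compound 3 to compound 4 is expected to be a 1.2-fold lower number from compound 3 to compound 4 (0.07 log units; within the scatter). For compound 4 the expected value is 20000 nM, estimated range 8000 nM to 50000 nM.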

Compound 4, half-maximal inhibitory concentration: 35200 nM
Compound 4: the middle estimate sits 1.8-fold (0.25 log units) below what was measured; low and high end bracket the measured number.
By their numbers in this assay, from the lowest: compounds 3, 1 and 4 (each within the scatter of the next). At a limit, above all of these: compound 2.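

In this assay methyl on an aromatic carbon, para to a large group, gives a 1.5-fold higher number from compound 3 to compound 4 (0.17 log units; within the scatter) and so, as the first change shown on the phenyl ring itself, does not separate the two compounds. Phenyl to 4-methylphenyl thus leaves the number within the scatter at this position, and the comparison with the benzyl urea, a 1.1-fold higher number from compound 1 to compound 4 (0.06 log units; within the scatter), is also within the scatter. Nothing shown bears on a cause for these steps.

From the compounds shown here alone, whether an amine or a carboxylic acid on this carbon would give a step beyond the scatter stays open.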